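Halogen exchange on the indole of compound 3

The source may hold more compounds than are shown below. What is called first, only, known or untested is meant among the compounds shown, and "the series" means these compounds.

Three compounds of the series have numbers in a functional assay on MV4-11 cells (Homo sapiens) for antiproliferative activity, read by CellTiter-Glo, with a stated time of 72 h; a higher number here means a weaker inhibitor, a lower number a stronger inhibitor. Compound 1 `CO[C@@H]1[C@H](N(C)c2ncc(-c3c[nH]c4ccc(F)cc34)s2)C[C@H]2O[C@]1(C)n1c3ccccc3c3c4c(c5c6ccccc6n2c5c31)C(=O)NC4` gives 510 nM. Compound 2 `CO[C@@H]1[C@H](N(C)c2ncc(-c3c[nH]c4ccc(Cl)cc34)s2)C[C@H]2O[C@]1(C)n1c3ccccc3c3c4c(c5c6ccccc6n2c5c31)C(=O)NC4` gives 420 nM. Compound 3 `CO[C@@H]1[C@H](N(C)c2ncc(-c3c[nH]c4ccc(F)cc34)s2)C[C@H]2O[C@]1(C)n1c3ccccc3c3c4c(c5c6cc(Cl)ccc6n2c5c31)C(=O)NC4` gives 320 nM, the lowest of the three numbers, although its distances to both other compounds lie within the scatter, so no order among the three can be read from this. The two single-point steps measured so far are a 1.2-fold lower number from compound 1 to compound 2 (0.08 log units; within the scatter) and a 1.6-fold lower number from compound 1 to compound 3 (0.20 log units; within the scatter); neither reaches beyond the scatter.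

Compound 4 `CO[C@@H]1[C@H](N(C)c2ncc(-c3c[nH]c4ccc(Br)cc34)s2)C[C@H]2O[C@]1(C)n1c3ccccc3c3c4c(c5c6cc(Cl)ccc6n2c5c31)C(=O)NC4` differs from compound 3 by bromo in place of fluoro on an aromatic carbon. Within the data shown here, the one earlier step that bears on this, an exchange of one halogen for another on an aromatic carbon, is a 1.2-fold lower number from compound 1 to compound 2 (0.08 log units; within the scatter), and it produced no movement beyond the scatter. Nothing measured speaks for a larger effect of bromo than of chloro at such a site. The expectation for compound 4 in this assay is therefore no step beyond the scatter, with at most a slight lowering of the number, expressed as a 1.1-fold lower number from compound 3 to compound 4 (0.06 log units; within the scatter). Compound 4 is accordingly estimated at 280 nM, with a range from 140 nM to 560 nM.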

Compound 4, half-maximal inhibitory concentration: 430 nM
Estimate against measurement, compound 4: 1.5-fold (0.19 log units) below; the measured number falls inside the stated range.
By their numbers in this assay, from the lowest: compounds 3, 2, 4 and 1 (each within the scatter of the next).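

Working notes on the halogen site: in this assay, replacing 5-fluoro-1H-indol-3-yl with 5-bromo-1H-indol-3-yl stays within the scatter (a 1.3-fold higher number from compound 3 to compound 4 (0.13 log units; within the scatter)), so bromo now joins fluoro and chloro as a halogen tolerated at this place on the six-membered aromatic ring. The earlier exchange of fluoro for chloro was read only on the core of compound 1, whereas this step extends the same flat reading to the core of compound 3, which carries an additional chloro; across these two single-place exchanges, no halogen swap at this site moves the number beyond the scatter. Nothing at hand explains this flat response or ties it to any property of the halogens.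

Whether this place responds to anything other than a halogen remains open, as the compounds shown do not tell whether a methoxy group, a nitrile, an amine or a carboxylic acid here would take the number beyond the scatter. Also open is how the unsubstituted indole compares, since every compound shown carries a halogen at this site.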